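A few compounds are considered here, and "the series" means these few. Any claim that something is new, unique, unknown or untested is made for them only; others in the source may bear on it.

Compounds measured in an assay on CHO cells for displacement of a labelled ligand from adenosine receptor A1 (Homo sapiens), read by scintillation counting, with a stated time of 60 min, tested at 10 uM; on this read-out higher numbers stand for more inhibition at the one concentration tested (going by the name of the read-out) and lower numbers for less inhibition: compound 1 `O=C(NCCCN1CCN(CCCNC(=O)c2cc3ccccc3oc2=O)CC1)c1cc2ccccc2oc1=O`; compound 2 `COCCNC(=O)c1cc2cccc(OC)c2oc1=N`; compound 3 `COc1cccc2cc(C(=O)Nc3c(C#N)ncn3-c3ccc(F)cc3)c(=N)oc12`.

In this assay compound 1 gives 9% and compound 3 gives 46%. Compound 2 gives only a limit, > 70%, the one described under (the limit of > 70% in this assay, at which 1 of the 3 values shown sits). Compound 2 therefore has no number of its own here, only that limit. Compound 4 `COc1cccc2cc(C(=O)NCCO)c(=N)oc12` is not yet measured; it differs from compound 2 by hydrogen in place of methyl on an oxygen on a saturated carbon. Among the compounds with values here, no step between measured compounds exists for this change, and compound 1 and compound 3 carry other cores and side chains. The step from compound 2 to compound 4 is expected to be small, within the scatter or a modest loss: a number at least 5 percentage points lower from compound 2 to compound 4 (that floor lies within the scatter). Compound 4 is expected to give about 65%, within 40% to 90%, with a fair chance of again being reported only as a limit.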

Compound 4, a percentage reported as inhibition, at one concentration (the size of the read-out at that concentration, not a potency): 47%
The estimate for compound 4 lay 18 percentage points above the measured number, within the range that was stated.
By their numbers in this assay, from the lowest: compound 1; then compounds 3 and 4 (each within the scatter of the next). At a limit, above all of these: compound 2.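

Within the data shown here, replacing methyl with hydrogen on an oxygen on a saturated carbon, 2-methoxyethyl to 2-hydroxyethyl, gives the first one-place comparison: in this assay it gives a number at least 23 percentage points lower from compound 2 to compound 4 (beyond the scatter). The methyl on this oxygen therefore matters to the read-out, and its loss lowers inhibition at the one concentration tested. The size of this step is only a bound, set by a limit: the limit of > 70% in this assay, at which 1 of the 4 values shown sits.

Going by these compounds, whether other groups on this chain would keep the higher inhibition remains open. An amine, a carboxylic acid or a longer chain in place of the 2-hydroxyethyl would test this.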